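This account rests on a few compounds, and the source may have more. Where it says the series, first, only, none or still open, it means among the compounds named here.

Working notes on the series.

Compound 1 `COC(=O)c1cc(-c2cccc(NC(=O)c3ccc(/C=C/C(=O)c4cccs4)cc3)c2)on1` carries a thiophene-bearing enone on the shared core; in an ADME assay on Vero cells (Chlorocebus sabaeus) for cytotoxicity, read by MTT assay, with a stated time of 72 h (on this read-out lower numbers stand for higher toxicity in this test and higher numbers for lower toxicity in this test), compound 1 gives "not determined" (no result reported), so no number is available for it. For the measured compounds named here, compound 2 `COC(=O)c1cc(-c2cccc(NC(=O)c3ccc(/C=C/C(=O)c4ccc(F)cc4F)cc3)c2)on1` is the only member with a result. In this assay compound 2 gives > 40 ug/mL, which is a limit of the assay rather than a number. On the numbers shown, compound 2 therefore stands at the limit described by the limit of > 40 ug/mL in this assay, at which 1 of the 2 values shown sits, and no step between measured compounds can be drawn from the pair.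

Compound 3 `COC(=O)c1cc(-c2cccc(NC(=O)c3ccc(/C=C/C(=O)c4cccc(OC)c4)cc3)c2)on1` differs from compound 2 by 3-methoxyphenyl in place of 2,4-difluorophenyl on a carbonyl carbon. Since compound 2 is known only as a limit, the step from compound 2 to compound 3 in this assay is expected to be none beyond the scatter, read as a step that the limit leaves unreadable from compound 2 to compound 3. For compound 3 in this assay the estimate is 60 ug/mL, in a range from 25 ug/mL to 150 ug/mL, most likely again reported only as a limit.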

Compound 3, half-maximal cytotoxic concentration: > 100 ug/mL
Compound 3: no number, only a limit; the forecaster's own chance of this, stated with the estimate: 70%; middle value at least 1.6-fold (0.22 log units) from the limit.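

In this assay, for the compounds shown here, compound 2 and compound 3 are each known only as a limit of the assay, and no step between them can be read. The compounds shown leave open whether 3-methoxyphenyl in place of 2,4-difluorophenyl on a carbonyl carbon changes the read-out at all.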